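The compounds below may be only part of what the source reports. "The series", "measured", "known", "first", "only" and "open" are said of these compounds alone.

Three ureas sharing one core have been measured in an ADME assay on the whole organism with Oryza sativa as the target, tested at 1 uM; on this read-out lower numbers stand for a stronger effect and higher numbers for a weaker effect at the one concentration tested. Compound 1 `Cc1ccccc1NC(=O)N[C@@H](C)c1ccccc1` gives 99% in this assay. Compound 2 `C[C@H](NC(=O)Nc1ccccc1Cl)c1ccccc1` gives 104%, and compound 3 `C[C@H](NC(=O)Nc1ccccc1I)c1ccccc1` gives 100%. The number of compound 2 is the highest of the three, but the step of a number 5 percentage points higher from compound 1 to compound 2 (within the scatter) and the step of a number 4 percentage points lower from compound 2 to compound 3 (within the scatter) both lie within the scatter, as does the step of a number 1 percentage points higher from compound 1 to compound 3 (within the scatter), so the three compounds are not set apart from one another by these data.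

Compound 4 `C[C@H](NC(=O)Nc1cc(Cl)ccc1Cl)c1ccccc1` is not yet measured. It differs from compound 2 by chloro in place of hydrogen on an aromatic carbon. For the measured compounds named here, no measured step adds a group where a hydrogen stood; the three measured steps each swap one group for another at a single aromatic carbon, and each of them stayed within the scatter. Going by the values given here, there is therefore no step in the data that speaks for a change beyond the scatter in this assay, and none that points to a direction. Compound 4 is accordingly expected to give 100% in this assay, within a range of 85% to 115%. This estimate means a step of a number 4 percentage points lower from compound 2 to compound 4 (within the scatter), which is expected to stay within the scatter.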

Compound 4, a percentage reported as activity, at one concentration (the size of the read-out at that concentration, not a potency): 99%
For compound 4 the middle estimate is 1 percentage points above the measured one; low and high end bracket the measured number.
By their numbers in this assay, from the lowest: compounds 1, 4, 3 and 2 (each within the scatter of the next).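

For the compounds shown here, the step of a number 5 percentage points lower from compound 2 to compound 4 (within the scatter) is the first in which a group enters where a hydrogen stood instead of replacing another group. It shows that a chloro group on this aromatic carbon, meta to a large group and para to a chloro group, does not set the two compounds apart in this assay. Until now, each step had only exchanged one group for another at a single aromatic carbon, and this one extends the same outcome to a ring carrying a further group, while no other data bear on the result.

The compounds shown leave open whether any group on this ring can move the number beyond the scatter, since the ring carries only methyl, chloro and iodo groups and hydrogen. An amine, a carboxylic acid or a methoxy group on the ring, or a longer chain in place of the methyl group of the shared core, could still give a different reading in this assay.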